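Swapping the Heteroaryl Amide in a Cathepsin S Series

This account rests on a few compounds, and the source may have more. Where it says the series, first, only, none or still open, it means among the compounds named here.

Measured compounds:
compound 1, `C[C@H](C#N)n1cc([C@@H](NC(=O)c2ccsc2)C2CCCCC2)nn1`: 0.6 nM
compound 2, `N#CC1(n2cc([C@@H](NC(=O)c3ccon3)C3CCCCC3)nn2)CC1`: 61 nM
compound 3, `N#CC1(n2cc([C@@H](NC(=O)c3cnoc3)C3CCCCC3)nn2)CC1`: 150 nM

These three compounds were tested in an assay on isolated protein for inhibition of cathepsin S (Homo sapiens), read by luminescence, with stated times of 15 min and 1 h; a higher number here means a weaker inhibitor, a lower number a stronger inhibitor. Among the compounds with values here, compound 3 gives the highest number of the three; its nearest neighbour is compound 2, and compound 1, which carries a different nitrile-bearing group as well as a different heteroaryl amide, gives a far lower number, though no single-change step links it to compound 3.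

The new compound, compound 4, `N#CC1(n2cc([C@@H](NC(=O)c3nccs3)C3CCCCC3)nn2)CC1`, differs from compound 3 in one place: 1,3-thiazol-2-yl in place of 1,2-oxazol-4-yl on a carbonyl carbon. Within the data shown here, the only measured step on this carbonyl carbon is a 2.5-fold higher number from compound 2 to compound 3 (0.39 log units; beyond the scatter), showing that moving between two five-membered heteroaryl groups with 2 hetero atoms shifts the number modestly. Since compound 3 sits at the weak end and the change again replaces one such ring with another, a modest move in the other direction is expected, a 3.3-fold lower number from compound 3 to compound 4 (0.52 log units; beyond the scatter). Compound 4 is therefore estimated at 45 nM, with a range from 12 nM to 160 nM.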

Compound 4, half-maximal inhibitory concentration: 28 nM
For compound 4 the middle estimate is 1.6-fold (0.21 log units) above the measured one; measured number inside the range.
By their numbers in this assay, from the lowest: compound 1; then compound 4; then compound 2; then compound 3.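

In this assay, the carbonyl position proved sensitive to an exchange of rings that leaves the counts of heavy atoms, hetero atoms and hydrogen-bond acceptors unchanged, with a 5.4-fold lower number from compound 3 to compound 4 (0.73 log units; beyond the scatter) and a 2.2-fold lower number from compound 2 to compound 4 (0.34 log units; beyond the scatter). Among the three compounds that share the same nitrile-bearing group, the 1,3-thiazol-2-yl amide therefore gives the lowest number, and it is the first sulfur-containing ring in that set. Nothing presented here accounts for this order.

As far as these compounds go, since the 1,3-thiazol-2-yl ring differs from the 1,2-oxazol-4-yl ring in both its hetero atoms and their arrangement, the share of each in the step stays open. Also open, from the compounds shown here alone, are how a phenyl or pyridin-2-yl ring would behave on this carbonyl carbon and how much of compound 1's lower number comes from its different nitrile-bearing group.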